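The compounds below may be only part of what the source reports. "The series", "measured", "known", "first", "only" and "open" are said of these compounds alone.

Measured compounds, read in a functional assay on MDBK cells (Bos taurus) for cytotoxicity; on this read-out higher numbers stand for lower toxicity in this test and lower numbers for higher toxicity in this test:
Compound 1 `Cc1ccc(O)c(C(=O)NCCCN2CCC[C@@H]3CCCC[C@@H]32)c1` gives > 100 ug/mL in this assay, which is a limit of the assay rather than a number.
Compound 2 `Cc1ccc(O)c(C(=O)NCCCN2C(C(C)C)CC[C@@H]3CCCC[C@@H]32)c1` gives 80 ug/mL in this assay.
Compound 3 `Cc1ccc(O)c(C(=O)NCCCN2CC(C)C[C@@H]3CCCC[C@@H]32)c1` gives 9.5 ug/mL in this assay.

Compound 1 thus sits at the limit of > 100 ug/mL in this assay, at which 1 of the 3 values shown sits; only a bound is known for it, so every measured step away from it is a floor. Compound 4 `Cc1ccc(O)c(C(=O)NCCCN2CCC(C)[C@@H]3CCCC[C@@H]32)c1` differs from compound 1 by methyl in place of hydrogen on a saturated ring carbon. Among the measured compounds shown here, two measured steps bear on this change, each adding a small alkyl group to a saturated ring carbon of the shared core: an at least 1.2-fold lower number from compound 1 to compound 2 (0.09 log units; that floor lies within the scatter) and an at least 10-fold lower number from compound 1 to compound 3 (1.02 log units; beyond the scatter). Compound 3 is the nearer precedent, since it also carries a methyl on a saturated ring carbon, though on another one. A step in the same direction is therefore expected in this assay, beyond the scatter, with a size that is uncertain between the two precedents. For compound 4 the expected value is 30 ug/mL, with a range of 8 ug/mL to 100 ug/mL. This amounts to an expected step of an at least 3.3-fold lower number from compound 1 to compound 4 (0.52 log units; beyond the scatter).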

Compound 4, half-maximal cytotoxic concentration: 100 ug/mL
The estimate for compound 4 lay 3.3-fold (0.52 log units) below the measured number; low and high end bracket the measured number.
By their numbers in this assay, from the lowest: compound 3; then compounds 2 and 4 (each within the scatter of the next).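

In this assay compound 4 gives 100 ug/mL and so stays far closer to the top of the shown range than compound 3 does at 9.5 ug/mL on the same read-out, with a number no higher from compound 1 to compound 4 (the limit leaves the size open). A methyl on this saturated ring carbon, next to the ring atom that bears a fused ring, therefore does not reproduce an at least 10-fold lower number from compound 1 to compound 3 (1.02 log units; beyond the scatter) and the effect of a methyl depends on which ring carbon carries it. Compound 1 gives > 100 ug/mL which is a limit of the assay, so the step to compound 4 cannot be read: the limit of > 100 ug/mL in this assay, at which 1 of the 4 values shown sits.

As far as these compounds go, whether compound 4 truly differs from compound 1 in this test remains open. Also open, from the compounds shown here alone, is how this ring carbon responds to a group other than methyl, such as a hydroxyl, an amine or a longer chain.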